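The source may report more compounds than this note shows. Statements on the series, on what has been measured and on what is new or still open speak of the compounds shown alone.

Measured compounds:
compound 1, `C/C(=N\O)c1ccc(NC(=O)Cn2nc(-c3ccc(Cl)cc3)nc2N)cc1`, gives 12% in a functional assay on SNB-75 cells (Homo sapiens) for inhibition, read by sulforhodamine B assay, with a stated time of 48 h, tested at 10 uM; on this read-out higher numbers stand for more inhibition of growth at the one concentration tested and lower numbers for less inhibition of growth.
compound 2, `COc1cc(-c2nc(N)n(CC(=O)Nc3ccc(/C(C)=N\O)cc3)n2)cc(OC)c1OC`, gives 25.9%.
compound 3, `C/C(=N/O)c1ccc(NC(=O)Cn2nc(-c3ccccc3)nc2N)cc1`, gives 22.5%.

Compound 3 stands second highest of the three numbers. Its nearest neighbour is compound 2, whose number lies within the scatter of it, so no order between these two can be read. Compound 1 lies further away, its number below that of compound 3 by more than the scatter.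

Compound 4, `C/C(=N/O)c1ccc(NC(=O)Cn2nc(C(F)(F)F)nc2N)cc1`, has not yet been measured. It differs from compound 3 in one place: trifluoromethyl in place of phenyl on an aromatic carbon. Among the measured compounds shown here, no step between measured compounds matches this change, so the expected size rests on the spread of the three numbers alone. The account expects a modest downward step, at about the edge of the scatter, that is a number 9.5 percentage points lower from compound 3 to compound 4 (within the scatter). Compound 4 is therefore estimated to give about 13%, with a range from 1% to 27%.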

Compound 4, percent growth inhibition at one concentration: 14.8%
Compound 4: middle estimate off by 1.8 percentage points, on the low side, within the range that was stated.
By their numbers in this assay, from the lowest: compounds 1, 4, 3 and 2 (each within the scatter of the next, the first and the last beyond it).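

Among the compounds shown here, compound 4 gives the first reading of this aromatic carbon, between two ring nitrogen atoms, with something other than a six-membered aromatic ring on it, as the earlier compounds all carry a phenyl or substituted phenyl group there. In this assay, for the compounds shown here, trifluoromethyl in place of phenyl gives a number 7.7 percentage points lower from compound 3 to compound 4 (within the scatter), so this exchange of a ring for a group with no ring shows no step that can be told from the scatter. The compounds shown offer no evidence that would explain this result.

From the compounds shown here alone, it remains open whether a methyl group, an amine or a carboxylic acid on this same carbon would stay within the scatter of compound 3. Equally open, going by these compounds, is whether a longer chain there would do so.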